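Adding 2-cyclopropylethynyl to the aromatic core of compound 1

This account rests on a few compounds, and the source may have more. Where it says the series, first, only, none or still open, it means among the compounds named here.

In a functional assay on K562 cells (Homo sapiens) for cytotoxicity, read by thymidine incorporation, with a stated time of 5 h, tested at 10 ug/mL (on this read-out higher numbers stand for more inhibition at the one concentration tested (going by the name of the read-out) and lower numbers for less inhibition), compound 1 `O=c1nc2c(cn1Cc1ccccc1)ncn2Cc1ccccc1` gives 16%, the lowest of the three numbers measured; compound 3 `CC1c2ncn(Cc3ccccc3)c2NC(=O)N1Cc1ccccc1` gives 76.4% and compound 2 `O=C1Nc2c(ncn2Cc2ccccc2)C(C#CC2CC2)N1Cc1ccccc1` gives 90%, and both gaps to compound 1 are beyond the scatter. Compound 4 `O=c1nc2c(ncn2Cc2ccccc2)c(C#CC2CC2)n1Cc1ccccc1` keeps the aromatic core of compound 1 and differs from it in one place: 2-cyclopropylethynyl in place of hydrogen on an aromatic carbon. For the measured compounds named here, the only measured step of one place, a number 13.6 percentage points lower from compound 2 to compound 3 (beyond the scatter), runs on the saturated core shared by compound 2 and compound 3 and compares 2-cyclopropylethynyl with methyl rather than with hydrogen; it puts the larger group on the higher side by a modest margin. Going by the values given here, no measured step separates the aromatic core of compound 1 from that saturated core, so the large gap from compound 1 to compound 2 and compound 3 cannot be assigned to the substituent alone. For compound 4 a rise is expected in this assay, a number 24 percentage points higher from compound 1 to compound 4 (beyond the scatter), clearly smaller than the gap between compound 1 and compound 2. Compound 4 is estimated at 40%, within a range of 15% to 75%.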

Compound 4, a percentage reported as inhibition, at one concentration (the size of the read-out at that concentration, not a potency): 98%
For compound 4 the middle estimate is 58 percentage points below the measured one; measured number outside the range, above it.
By their numbers in this assay, from the lowest: compound 1; then compound 3; then compounds 2 and 4 (each within the scatter of the next).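

In this assay the change of hydrogen to 2-cyclopropylethynyl on this aromatic carbon, next to the ring nitrogen and ortho to a benzyl group, gives a number 82 percentage points higher from compound 1 to compound 4 (beyond the scatter) and so ties a large step to this one substituent on the core of compound 1. The earlier single-place step, a number 13.6 percentage points lower from compound 2 to compound 3 (beyond the scatter), compared the group only with methyl on a saturated ring carbon and could not show what it adds over hydrogen on the aromatic core. Nothing available here accounts for the size of this step.

The compounds shown leave open whether the step needs the whole 2-cyclopropylethynyl group, or whether a plain ethynyl, a methyl or an amine on the same carbon would give a similar number. With one concentration tested, they also leave open how compound 1 and compound 4 differ in potency.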